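Notes on Compound 3 Beside Compounds 1 and 2

The source may report more compounds than this note shows. Statements on the series, on what has been measured and on what is new or still open speak of the compounds shown alone.

Measured so far:
- compound 1 `COc1cc(-n2cnc3ccc(-c4ccccc4Cl)cc32)cc(OC)c1OC`: > 10000 nM
- compound 2 `COc1cc(-n2cnc3ccc(-c4cccc(Cl)c4)cc32)cc(OC)c1OC`: 1490 nM

In a functional assay on SGC-7901 cells (Homo sapiens) for antiproliferative activity, read by MTT assay, with a stated time of 72 h (a lower number here means a stronger inhibitor, a higher number a weaker inhibitor), compound 1 reaches only a limit of the assay, not a number. Compound 2 in this assay gives 1490 nM. Within the data shown here, the one step between them, an at least 6.7-fold lower number from compound 1 to compound 2 (0.82 log units; beyond the scatter), is therefore the only measured guide in the set, and it rests on (the limit of > 10000 nM in this assay, at which 1 of the 2 values shown sits).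

Compound 3 `COc1cc(-n2cnc3ccc(-c4cccc(C)c4)cc32)cc(OC)c1OC` is not yet measured in this assay. Against compound 1 the change is 3-methylphenyl in place of 2-chlorophenyl on an aromatic carbon. Among the measured compounds shown here, this shares with the step from compound 1 to compound 2 the loss of the 2-chlorophenyl group, but the entering 3-methylphenyl group has no measured counterpart here, so the size carried over from an at least 6.7-fold lower number from compound 1 to compound 2 (0.82 log units; beyond the scatter) is uncertain and only its direction is taken as a hint. A lower number than compound 1 is expected, with the caution that compound 1 itself is known only as a limit.

The expected step is an at least 4.0-fold lower number from compound 1 to compound 3 (0.60 log units; beyond the scatter), read as an expectation rather than a measurement. For compound 3 in this assay the estimate is 2500 nM, with a range from 700 nM to 9000 nM.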

Compound 3, half-maximal inhibitory concentration: 1240 nM
Compound 3: middle estimate off by 2.0-fold (0.30 log units), on the high side; measured number inside the range.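

Replacing chloro with methyl on the same phenyl ring gives a 1.2-fold lower number from compound 2 to compound 3 (0.08 log units; within the scatter), so in this assay the 3-chlorophenyl and 3-methylphenyl groups cannot be told apart, and the number of compound 2 does not depend on chloro as such. Compound 3 also gives a second step away from the 2-chlorophenyl group of compound 1, an at least 8.0-fold lower number from compound 1 to compound 3 (0.90 log units; beyond the scatter), in the same direction as the step to compound 2, so two different 3-substituted phenyl groups now stand against the one 2-substituted phenyl group shown. Both steps from compound 1 have a size that is only a lower bound, which the series cannot sharpen, since compound 1 is known only as a limit: the limit of > 10000 nM in this assay, at which 1 of the 3 values shown sits.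

The compounds shown leave open how far the tolerance at this place on the phenyl ring extends, for instance whether an amine, a carboxylic acid or a chain longer than methyl would keep the number close to those of compound 2 and compound 3. They also leave open whether the loss seen with compound 1 belongs to chloro or to any group at that place on the ring.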